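Bromo for methyl on the pyrazoline aryl of compound 2

This account rests on a few compounds, and the source may have more. Where it says the series, first, only, none or still open, it means among the compounds named here.

Measured so far in a functional assay on MCF7 cells (Homo sapiens) for antiproliferative activity, read by MTT assay, with a stated time of 48 h; on this read-out lower numbers stand for stronger inhibition and higher numbers for weaker inhibition:
compound 1 `Cc1ccc(C2=NN(c3nc(-c4ccc(Br)cc4)cs3)C(c3cccs3)C2)cc1` gives 2010 nM;
compound 2 `Cc1ccc(C2=NN(c3nc(-c4ccccc4)cs3)C(c3cccs3)C2)cc1` gives 18600 nM;
compound 3 `Cc1ccc(C2=NN(c3nc(-c4ccc(C(F)(F)F)cc4)cs3)C(c3cccs3)C2)cc1` gives 31500 nM.

Compound 2 stands second highest of the three numbers in this assay ; its nearest neighbour is compound 3, the step from compound 2 to compound 3 being a 1.7-fold higher number from compound 2 to compound 3 (0.23 log units; within the scatter), while the step from compound 1 to compound 2 is a 9.3-fold higher number from compound 1 to compound 2 (0.97 log units; beyond the scatter). Compound 4 `Brc1ccc(C2=NN(c3nc(-c4ccccc4)cs3)C(c3cccs3)C2)cc1` differs from compound 2 by bromo in place of methyl on an aromatic carbon, on the 4-methylphenyl ring attached to the shared core rather than on the aryl of compound 1 that carries the bromo. Going by the values given here, no measured step changes this ring. The steps known, a 9.3-fold higher number from compound 1 to compound 2 (0.97 log units; beyond the scatter) and a 16-fold higher number from compound 1 to compound 3 (1.20 log units; beyond the scatter), concern the other aryl, so they bear only loosely on this change; they hint that a bromo can lower the number where a hydrogen or trifluoromethyl does not. Compound 4 is therefore expected at 10000 nM, within 3000 nM to 40000 nM, the expected step from compound 2 to compound 4 being a 1.9-fold lower number from compound 2 to compound 4 (0.27 log units; within the scatter), a modest lowering at most.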

Compound 4, half-maximal inhibitory concentration: 6790 nM
Beside the measured number, compound 4's estimate is 1.5-fold (0.17 log units) above it; measured number inside the range.
By their numbers in this assay, from the lowest: compound 1; then compound 4; then compounds 2 and 3 (each within the scatter of the next).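

Exchanging 4-methylphenyl for 4-bromophenyl on the shared core gives a 2.7-fold lower number from compound 2 to compound 4 (0.44 log units; beyond the scatter) in this assay. Going by these compounds alone, the earlier steps touched only the other aryl, so this is the first reading at this ring, and it shows that the number responds here too, even though one heavy atom simply replaces another and the counts of donors, acceptors and charge stay the same. Nothing in the information available accounts for this step.

With only methyl and bromo seen on this ring, the compounds shown leave open how hydrogen, a methoxy group, an amine or a carboxylic acid would read at the same place. They also leave open whether the step would hold with a bromo or a trifluoromethyl on the other aryl.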